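Swapping Fluoro for Methyl on the Aryl Ring

The source may hold more compounds than are shown below. What is called first, only, known or untested is meant among the compounds shown, and "the series" means these compounds.

Compound 1 `COc1cccc(N2CCN(C(=O)C(C)N3C(=O)CCC3=O)CC2)c1` gives 0% in a functional assay on the whole organism (strain Swiss) with Mus musculus as the target, in the maximal electroshock model, with a stated time of 2 h, at a dose of 300 mg/kg by the intraperitoneal route; on this read-out lower numbers stand for a weaker effect and higher numbers for a stronger effect at the one dose given.
Compound 2 `CC(C(=O)N1CCN(c2ccccc2F)CC1)N1C(=O)CCC1=O` gives 25% in this assay.
Compound 3 `CC(C(=O)N1CCN(c2cccc(F)c2)CC1)N1C(=O)CCC1=O` gives 100% in this assay.

Compound 3 stands highest of the three numbers. The steps of a number 75 percentage points higher from compound 2 to compound 3 (beyond the scatter) and a number 100 percentage points higher from compound 1 to compound 3 (beyond the scatter) both lie beyond the usual scatter, so its lead over the other two is real.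

Compound 4 `Cc1cccc(N2CCN(C(=O)C(C)N3C(=O)CCC3=O)CC2)c1` differs from compound 3 in one place: methyl in place of fluoro on an aromatic carbon. Within the data shown here, the one measured step at this same aromatic carbon is a number 100 percentage points higher from compound 1 to compound 3 (beyond the scatter), a large rise when methoxy gave way to fluoro. The other two steps, a number 25 percentage points higher from compound 1 to compound 2 (beyond the scatter) and a number 75 percentage points higher from compound 2 to compound 3 (beyond the scatter), move the substituent around the ring rather than exchanging it, so they bear less directly. Among the measured compounds shown here, no measured step covers methyl itself, so the size of the change is open; since compound 3 already sits at the top of the scale, the number for compound 4 can only stay or fall.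

A moderate fall is therefore expected for compound 4, a number 50 percentage points lower from compound 3 to compound 4 (beyond the scatter), because the step of a number 100 percentage points higher from compound 1 to compound 3 (beyond the scatter) shows that the group at this carbon matters greatly. Compound 4 is estimated at 50%, within a wide range from 0% to 100%.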

Compound 4, a percentage reported as activity, at one dose (the size of the read-out at that dose, not a potency): 0%
Compound 4: the middle estimate sits 50 percentage points above what was measured, within the range that was stated.
By their numbers in this assay, from the lowest: compounds 1 and 4 (each within the scatter of the next); then compound 2; then compound 3.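

The exchange of fluoro for methyl, one heavy atom for another, brings a number 100 percentage points lower from compound 3 to compound 4 (beyond the scatter) in this assay, so the high read-out of compound 3 does not carry over to every small group at this aromatic carbon. Methyl and methoxy cannot be told apart here, with no change at the digits printed from compound 1 to compound 4 (within the scatter), which leaves fluoro as the only one of the three groups tried at this carbon that goes with a clear effect. The 3-methylphenyl group also falls short of the 2-fluorophenyl group, with a number 25 percentage points lower from compound 2 to compound 4 (beyond the scatter), so the 2-fluorophenyl compound, though well behind compound 3, still keeps an effect that compound 4 lacks.

Nothing in the data given explains why fluoro and methyl part so sharply at this carbon. Whether chloro, hydroxyl or an amine at this carbon would keep the effect stays open, as does the ranking of these compounds at lower doses, where differences hidden by the single dose and the top of the scale might appear.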